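The source may hold more compounds than are shown below. What is called first, only, known or untested is meant among the compounds shown, and "the series" means these compounds.

The measured compounds are:

compound 1, `O=C(NCCCCc1ccccc1)c1cccc(C2SCC(=O)N2c2ccccc2)c1`, which in a functional assay on HOS-TE85 cells (Homo sapiens) for inhibition, read by CCK-8 assay, with a stated time of 72 h, tested at 1 uM (a lower number here means less inhibition, a higher number more inhibition at the concentration tested (going by the name of the read-out)), gives 96%
compound 2, `Cc1cccc(N2C(=O)CSC2c2cccc(C(=O)NCCCCc3ccccc3)c2)c1`, which in this assay gives 96%
compound 3, `O=C(NCCCCc1ccccc1)c1cccc(C2SCC(=O)N2c2ccccc2F)c1`, which in this assay gives 95%

Compound 3 holds the lowest of the three numbers, but only nominally: the nearest value is that of compound 1 and the furthest that of compound 2, and both gaps lie within the scatter. The steps recorded so far are no change at the digits printed from compound 1 to compound 2 (within the scatter), a number 1 percentage points lower from compound 1 to compound 3 (within the scatter) and a number 1 percentage points lower from compound 2 to compound 3 (within the scatter), none of them beyond the scatter. All three measured compounds share the same core and differ only in the ring carried on the amide-type nitrogen of the five-membered ring, and that ring has so far made no difference to the read-out.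

Compound 4, `COc1ccc(N2C(=O)CSC2c2cccc(C(=O)NCCCCc3ccccc3)c2)c(OC)c1`, continues this series. Its change from compound 3 is 2,4-dimethoxyphenyl in place of 2-fluorophenyl on an amide-type nitrogen in a ring. Going by the values given here, the steps that bear on it are the two that also alter the ring on this nitrogen, a number 1 percentage points lower from compound 2 to compound 3 (within the scatter) and, one position removed, a number 1 percentage points lower from compound 1 to compound 3 (within the scatter); both were flat. A larger group enters than in any measured case, so some reservation is due, but nothing measured points to a drop. Compound 4 is therefore expected to give 93%, with a likely range from 78% to 99%. The expected step is a number 2 percentage points lower from compound 3 to compound 4 (within the scatter), within the scatter.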

Compound 4, a percentage reported as inhibition, at one concentration (the size of the read-out at that concentration, not a potency): 58%
Beside the measured number, compound 4's estimate is 35 percentage points above it; the whole stated range lies above it.
By their numbers in this assay, from the lowest: compound 4; then compounds 3, 1 and 2 (each within the scatter of the next).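

The ring on the amide-type nitrogen of the five-membered ring turns out not to leave the number unchanged in this assay: 2,4-dimethoxyphenyl brings a number 37 percentage points lower from compound 3 to compound 4 (beyond the scatter) and a number 38 percentage points lower from compound 2 to compound 4 (beyond the scatter) as well as a number 38 percentage points lower from compound 1 to compound 4 (beyond the scatter) while phenyl, 3-methylphenyl and 2-fluorophenyl could not be told apart. Going by these compounds alone, the level numbers seen with the earlier compounds therefore do not hold for every aryl group at this place, although a single compound cannot show how far they hold. The entering group has 10 heavy atoms and 2 hydrogen-bond acceptors against 7 heavy atoms and 0 hydrogen-bond acceptors for 2-fluorophenyl, so size and oxygen content change together here, and no measurement in hand explains the loss of inhibition.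

The compounds shown leave open whether one methoxy group on the phenyl ring would be enough for such a step or whether both are needed. They also leave open how a hydroxy group, an ethoxy group or a dimethylamino group would read at this place on the ring.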